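The source may hold more compounds than are shown below. What is called first, only, known or untested is meant among the compounds shown, and "the series" means these compounds.

Compound 1 `Cc1ccc(Cn2cc(COc3ccc4c(=O)ccoc4c3)nn2)cc1`: in a functional assay on SGC-7901 cells (Homo sapiens) for cytotoxicity, read by MTT assay, with a stated time of 48 h (on this read-out lower numbers stand for stronger inhibition and higher numbers for weaker inhibition), compound 1 gives > 100000 nM, which is a limit of the assay, not a number.
Compound 2 `N#Cc1ccc(Cn2cc(COc3ccc4c(=O)ccoc4c3)nn2)cc1`: compound 2 gives > 100000 nM, again a limit.
Compound 3 `O=c1ccoc2cc(OCc3cn(Cc4cccc(F)c4)nn3)ccc12`: compound 3 gives > 100000 nM, also a limit.

All three measured compounds sit at the same point, (the limit of > 100000 nM in this assay, at which 3 of the 3 values shown sit), so compound 3 stands level with its two companions and no order among them can be read. The three single-point steps, a step that the two limits leave unreadable from compound 1 to compound 2, a step that the two limits leave unreadable from compound 1 to compound 3 and a step that the two limits leave unreadable from compound 2 to compound 3, are for the same reason unreadable in size: exchanging methyl, cyano or fluoro on the pendant phenyl group, or moving between 4-methylphenyl, 4-cyanophenyl and 3-fluorophenyl, left every compound at the limit.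

Compound 4 `O=c1ccoc2cc(OCc3cn(Cc4cccc(Br)c4)nn3)ccc12` differs from compound 3 by bromo in place of fluoro on an aromatic carbon. No measured step concerns this exact change; the three steps shown only tell that varying this outer phenyl group has so far produced nothing readable. The expected step from compound 3 to compound 4 is therefore a step that the limit leaves unreadable from compound 3 to compound 4, meaning no change beyond the scatter. Compound 4 is thus estimated at 150000 nM, within 50000 nM to 500000 nM, and most likely the assay will again report only a limit.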

Compound 4, half-maximal inhibitory concentration: > 100000 nM
Compound 4 gave a limit, no number; the forecaster's own chance of this, stated with the estimate: 80%; the middle value is on the limit's open side.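

Among the compounds shown here, compound 4 is again only a limit, so no step between it and compound 1, compound 2 or compound 3 can be read, because all four sit at the same point: the limit of > 100000 nM in this assay, at which 4 of the 4 values shown sit.

These compounds leave open whether any change to the pendant phenyl group or the shared core would give a real number in this assay, and how they truly rank.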